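From Acetoxy to (Cyclohexylcarbonyl)oxy

The compounds below may be only part of what the source reports. "The series", "measured", "known", "first", "only" and "open" are said of these compounds alone.

In an ADME assay on L6 cells (Rattus norvegicus) for cytotoxicity, read by resazurin assay, with a stated time of 70 h (a higher number here means a weaker inhibitor, a lower number a stronger inhibitor), compound 1 (`CC(=O)Oc1ccc2c(c1)C(C)=CC(C)(C)N2Cc1ccccc1`) gives 24000 nM and compound 2 (`CC(=O)Oc1ccc2c(c1)C(C)=CC(C)(C)N2Cc1cccc(C)c1`) gives 28000 nM, so the two lie within the scatter of each other. Compound 3 (`CC1=CC(C)(C)N(Cc2ccccc2)c2ccc(OC(=O)C3CCCCC3)cc21`) has cyclohexyl in place of methyl on a carbonyl carbon. Among the measured compounds shown here, the only measured step, a 1.2-fold higher number from compound 1 to compound 2 (0.07 log units; within the scatter), is methyl in place of hydrogen on an aromatic carbon, elsewhere in the molecule, so it bears only loosely on this change. For the measured compounds named here, no measured step covers the carbonyl carbon, so little movement is expected. The estimated step is a 1.2-fold lower number from compound 1 to compound 3 (0.08 log units; within the scatter). For compound 3 the expected value is 20000 nM, with an estimated range of 7000 nM to 60000 nM.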

Compound 3, half-maximal inhibitory concentration: > 230000 nM
Compound 3 gave a limit, no number (the forecaster's own chance of this, stated with the estimate: 10%); middle value at least 11-fold (1.06 log units) from the limit.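

The carbonyl carbon proves to be a place where the number responds: in this assay, cyclohexyl in place of methyl gives an at least 9.5-fold higher number from compound 1 to compound 3 (0.98 log units; beyond the scatter), whereas the earlier change on an aromatic carbon gave a 1.2-fold higher number from compound 1 to compound 2 (0.07 log units; within the scatter). Compound 3 gives a limit of the assay and not a number, so the full size of this step stays unknown: the limit of > 230000 nM in this assay, at which 1 of the 3 values shown sits.

The compounds shown leave open whether an ethyl group or a longer chain on this carbonyl carbon would already give such a step. They also leave open what a phenyl ring or an amine there would do.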